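This account rests on a few compounds, and the source may have more. Where it says the series, first, only, none or still open, it means among the compounds named here.

Measured in a functional assay on MCF7 cells (Homo sapiens) for inhibition, read by sulforhodamine B assay; on this read-out higher numbers stand for weaker inhibition of growth and lower numbers for stronger inhibition of growth:

- Compound 1 `COc1ccc(-c2ccc(-c3ccc(-c4nc5cc(C)ccc5[nH]4)cc3)cc2)cc1OC`: 190 nM
- Compound 2 `Fc1ccc(-c2ccc(-c3ccc(-c4nc5ccccc5[nH]4)cc3)cc2)cc1`: 36200 nM

Of these two numbers, compound 2 at 36200 nM has the higher, and the gap to compound 1 at 190 nM lies well beyond the scatter. Compound 2 is therefore the weaker growth inhibitor of the pair.

Compound 3 `Cc1ccc2[nH]c(-c3ccc(-c4ccc(-c5ccc(F)cc5)cc4)cc3)nc2c1` departs from compound 2 in one place: methyl in place of hydrogen on an aromatic carbon. In words, it has methyl in place of hydrogen on an aromatic carbon. Within the data shown here, no measured pair isolates this change. Compound 1 also carries a methyl, but it differs from compound 2 at a second place as well, so the value of compound 1 at 190 nM offers only a loose hint of direction. A moderate move towards a lower number in this assay is therefore expected, much smaller than the gap between the two measured compounds, and a result close to compound 2 would not be surprising. The estimated change is a 3.6-fold lower number from compound 2 to compound 3 (0.56 log units; beyond the scatter). For compound 3 the expected value is 10000 nM, with an estimated range of 1500 nM to 50000 nM.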

Compound 3, concentration for 50% growth inhibition: 30200 nM
Estimate against measurement, compound 3: 3.0-fold (0.48 log units) below; measured number inside the range.
By their numbers in this assay, from the lowest: compound 1; then compounds 3 and 2 (each within the scatter of the next).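

In this assay, methyl in place of hydrogen on this aromatic carbon, part of a fused system of two rings, gives a 1.2-fold lower number from compound 2 to compound 3 (0.08 log units; within the scatter), so with the 4-fluorophenyl group present, this methyl leaves the number within the scatter. The other change now reads on its own: 4-fluorophenyl in place of 3,4-dimethoxyphenyl gives a 160-fold higher number from compound 1 to compound 3 (2.20 log units; beyond the scatter), and with the methyl held constant, this single change accounts for a large difference, which the earlier pair of compounds, differing in two places, could not isolate. Nothing at hand explains either step.

The compounds shown leave open whether the methyl would also make so little difference with the 3,4-dimethoxyphenyl group in place, since that comparison would need the counterpart of compound 1 with hydrogen on this carbon. They also leave open how an amine, a carboxylic acid or a longer chain such as propyl on this same aromatic carbon would read, and which of the two methoxy groups matters to the large step seen with compound 1 and compound 3.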